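The source may hold more compounds than are shown below. What is called first, only, known or untested is meant among the compounds shown, and "the series" means these compounds.

Measured compounds:
compound 1 `Cc1cccc(N(C)S(=O)(=O)C2CC3OC2C(c2ccc(NC(=O)CCCCCCC(=O)O)cc2)=C3c2ccc(O)cc2)c1` — 30200 nM
compound 2 `CN(c1ccccc1Cl)S(=O)(=O)C1CC2OC1C(c1ccc(NC(=O)CCCCCCC(=O)O)cc1)=C2c1ccc(O)cc1` — 12800 nM
compound 3 `CCN(c1ccccc1)S(=O)(=O)C1CC2OC1C(c1ccc(NC(=O)CCCCCCC(=O)O)cc1)=C2c1ccc(O)cc1` — 19100 nM

All three share a core and differ only in the amine on the sulfonyl sulfur. In a functional assay on MCF7 cells (Homo sapiens) for antiproliferative activity, read by MTT assay, with a stated time of 72 h (on this read-out lower numbers stand for stronger inhibition and higher numbers for weaker inhibition), compound 2 gives the number that is beyond the scatter from compound 1, as the step of a 2.4-fold lower number from compound 1 to compound 2 (0.37 log units; beyond the scatter) shows, while compound 2 and compound 3 lie within the scatter of each other (a 1.5-fold higher number from compound 2 to compound 3 (0.17 log units; within the scatter)). The step of a 1.6-fold lower number from compound 1 to compound 3 (0.20 log units; within the scatter) is likewise within the scatter. No substituent change on this amine has so far moved the read-out by much.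

Compound 4 `CCN(c1ccc(O)cc1)S(=O)(=O)C1CC2OC1C(c1ccc(NC(=O)CCCCCCC(=O)O)cc1)=C2c1ccc(O)cc1` is the next member. Relative to compound 2 the change is ethyl(4-hydroxyphenyl)amino in place of (2-chlorophenyl)(methyl)amino on a sulfonyl sulfur. Among the compounds with values here, the step that bears most directly on it is the one from compound 2 to compound 3, which swaps the same leaving group for ethyl(phenyl)amino and stays within the scatter. Within the data shown here, a hydroxyl on that phenyl ring has no measured precedent, so nothing speaks for a large move in either direction. Compound 4 is therefore expected to sit near compound 2 and compound 3, with a step of a 1.5-fold higher number from compound 2 to compound 4 (0.17 log units; within the scatter) that is expected to remain within the scatter. The estimated value for compound 4 is 19000 nM, with a range of 8000 nM to 45000 nM.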

Compound 4, half-maximal inhibitory concentration: 46600 nM
For compound 4 the middle estimate is 2.5-fold (0.39 log units) below the measured one; the measured number lies above the stated range.
By their numbers in this assay, from the lowest: compounds 2, 3, 1 and 4 (each within the scatter of the next, the first and the last beyond it).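

In this assay, hydroxy in place of hydrogen on an aromatic carbon of the ethyl(phenyl)amino group gives a 2.4-fold higher number from compound 3 to compound 4 (0.39 log units; beyond the scatter), the first single-substituent change on this amine shown to raise the number beyond the scatter. Within the data shown here, measured against the (2-chlorophenyl)(methyl)amino group, ethyl(4-hydroxyphenyl)amino gives a 3.6-fold higher number from compound 2 to compound 4 (0.56 log units; beyond the scatter), the largest step so far, whereas against the methyl(3-methylphenyl)amino group it gives a 1.5-fold higher number from compound 1 to compound 4 (0.19 log units; within the scatter), so the sulfonamide nitrogen substituents do affect the read-out, but compound 4 remains unresolved from compound 1. No evidence is available to explain these steps.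

Open, on these data alone, is whether the step from compound 3 to compound 4 is specific to the hydroxyl, which 4-methoxyphenyl, 4-aminophenyl or 4-carboxyphenyl groups on the same nitrogen would test. Also open, as far as these compounds go, is whether the hydroxyl gives a similar step with methyl rather than ethyl on that nitrogen, as in a methyl(4-hydroxyphenyl)amino group, or on a ring that also carries chlorine.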